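The source may report more compounds than this note shows. Statements on the series, on what has been measured and on what is new or still open speak of the compounds shown alone.

For the measured compounds named here, in a physicochemical assay for solubility, in phosphate buffer, measured as kinetic solubility (on this read-out higher numbers stand for higher solubility and lower numbers for lower solubility), compound 1 `CC(C)C(/C=C1\NC(=O)NC1=O)c1ccc(-c2ccc3cccc(F)c3c2)[nH]c1=O` gives 10700 nM and holds the lower of the two numbers so far. In this assay compound 2 `CC(C)[C@@H](c1ccc(-c2ccc3cccc(F)c3c2)[nH]c1=O)[C@@H]1OC(=O)NC1=O` gives the higher number, 27400 nM and this gap lies beyond the usual scatter of repeat measurements.

Compound 3 `CC(C)C(c1ccc(-c2ccc3cccc(F)c3c2)[nH]c1=O)C1NC(=O)NC1=O` has not yet been measured. It differs from compound 1 in one place: a group of 7 heavy atoms (3 carbon, 2 nitrogen, 2 oxygen; one five-membered non-aromatic ring with 2 hetero atoms) in place of a group of 8 heavy atoms (4 carbon, 2 nitrogen, 2 oxygen; one five-membered non-aromatic ring with 2 hetero atoms), on a saturated chain carbon bound to an aromatic carbon and a saturated chain carbon is the change, with 2,5-dioxoimidazolidin-4-yl as the entering group, on a saturated chain carbon bound to an aromatic carbon and a saturated chain carbon.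

Going by the values given here, no pair of measured compounds differs in just one place, so this change has no direct precedent in the data. Among the compounds with values here, the only guide is compound 2 at 27400 nM whose ring looks more like the entering group than the departing group of compound 1 does. On that thin evidence, a modest rise is expected, an estimated 2.3-fold higher number from compound 1 to compound 3 (0.37 log units; beyond the scatter) that would lie only slightly beyond the scatter. In this assay compound 3 is expected at about 25000 nM with an estimated range from 10000 nM to 60000 nM on this basis.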

Compound 3, solubility: 10600 nM
The estimate for compound 3 lay 2.4-fold (0.37 log units) above the measured number; measured number inside the range.
By their numbers in this assay, from the lowest: compounds 3 and 1 (each within the scatter of the next); then compound 2.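

In this assay, the exchange at this saturated chain carbon gives a 1.0-fold lower number from compound 1 to compound 3 (0.00 log units; within the scatter) and so leaves the two compounds indistinguishable on this read-out. The departing group and the entering 2,5-dioxoimidazolidin-4-yl share a five-membered non-aromatic ring with 2 hetero atoms, 2 hydrogen-bond donors and 2 hydrogen-bond acceptors, while they differ in having 8 against 7 heavy atoms and 3 against 2 double bonds outside aromatic rings; at this position, that particular set of differences comes with no measurable shift. Nothing else measured here helps to explain this result.

Going by these compounds, the pair speaks only for these two closely matched ring groups, so it remains open how a carboxylic acid, an amine or a longer chain on the same carbon would read in this assay and whether any of them would move the number beyond the scatter. On these data alone, it also remains open whether the same exchange would give a similar step on a core other than that of compound 1.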